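A Methyl to Ethyl Step on the Piperazine

The source may report more compounds than this note shows. Statements on the series, on what has been measured and on what is new or still open speak of the compounds shown alone.

In a functional assay on KYSE-450 cells (Homo sapiens) for inhibition, read by CCK-8 assay, with a stated time of 48 h (a higher number here means a weaker inhibitor, a lower number a stronger inhibitor), compound 1 `CCN1CCN(C(=S)SCC(=O)N(Cc2ccc(OC)cc2)c2cc(OC)c(OC)c(OC)c2)CC1` gives 3070 nM and compound 2 `COc1ccc(CN(C(=O)CSC(=S)N2CCN(C(=O)OC(C)(C)C)CC2)c2cc(OC)c(OC)c(OC)c2)cc1O` gives 76 nM. Compound 3 `COc1ccc(CN(C(=O)CSC(=S)N2CCN(C)CC2)c2cc(OC)c(OC)c(OC)c2)cc1O` gives 760 nM, the second highest of the three numbers. Compound 4 `CCN1CCN(C(=S)SCC(=O)N(Cc2ccc(OC)c(O)c2)c2cc(OC)c(OC)c(OC)c2)CC1` differs from compound 3 by methyl in place of hydrogen on a saturated chain carbon bound to an amine nitrogen in a ring, so 4-methylpiperazin-1-yl becomes 4-ethylpiperazin-1-yl. Within the data shown here, the only measured step at this nitrogen is a 10-fold higher number from compound 2 to compound 3 (1.00 log units; beyond the scatter), a much larger exchange of groups. Compound 1 carries the same ethyl but differs elsewhere too, so it offers no clean comparison. No change beyond the scatter is therefore expected, and no direction is favoured. The expected result is a 1.1-fold higher number from compound 3 to compound 4 (0.02 log units; within the scatter). For compound 4 the estimated value is 800 nM, with an expected range of 300 nM to 2200 nM.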

Compound 4, half-maximal inhibitory concentration: 320 nM
Estimate against measurement, compound 4: 2.5-fold (0.40 log units) above, and the stated range covers the measured number.
By their numbers in this assay, from the lowest: compound 2; then compound 4; then compound 3; then compound 1.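

In this assay, the single added methyl that turns 4-methylpiperazin-1-yl into 4-ethylpiperazin-1-yl gives a 2.4-fold lower number from compound 3 to compound 4 (0.38 log units; beyond the scatter), so even this small change at the ring nitrogen substituent registers beyond the scatter. Ethyl still falls short of tert-butoxycarbonyl, with a 4.2-fold higher number from compound 2 to compound 4 (0.62 log units; beyond the scatter), while with ethyl held fixed, hydroxy in place of hydrogen on an aromatic carbon gives a 9.6-fold lower number from compound 1 to compound 4 (0.98 log units; beyond the scatter). No evidence here accounts for these steps.

Going by these compounds, whether a propyl or a cyclopropyl group on this nitrogen would continue the drop from methyl to ethyl remains open, as does how an acetyl group would compare with tert-butoxycarbonyl.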